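The compounds below may be only part of what the source reports. "The series", "measured", "known", "first", "only" and "open" are said of these compounds alone.

Measured so far:
Compound 1, `CCCCNc1nc(N)c2nc(O)n(Cc3ccc(C)cc3)c2n1`: in a physicochemical assay for solubility, at pH 7.4 (a lower number here means a less soluble compound, a higher number a more soluble compound), compound 1 is reported only as a limit, < 1000 ug/mL.
Compound 2, `CCCCNc1nc(N)c2[nH]c(=O)n(Cc3ccc(OCCCN(C)C)nc3)c2n1`: in this assay compound 2 gives 288000 ug/mL.

Going by the values given here, compound 2 holds the only numerical value in this assay; the other value is a limit, (the limit of < 1000 ug/mL in this assay, at which 1 of the 2 values shown sits). Among the compounds with values here, the two values therefore show no more than that compound 1 sits at the limit while compound 2 is measured as a number, and no step between measured compounds can be stated.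

Compound 3, `CCCCNc1nc(N)c2[nH]c(=O)n(Cc3ccc(OCCCCN(C)C)nc3)c2n1`, has not yet been measured in this assay. It differs from compound 2 by (dimethylamino)methyl in place of dimethylamino on a saturated chain carbon, three bonds along the chain from an oxygen on an aromatic ring. The chain is longer by one saturated carbon, as counted there, with the same donor and acceptor count and no change in charge. Within the data shown here, no measured step bears on a change of this kind, so the direction is taken as open, with a lean toward a slightly lower value. For compound 3 in this assay the expected value is 200000 ug/mL, with a range from 100000 ug/mL to 400000 ug/mL. The step this implies, a 1.4-fold lower number from compound 2 to compound 3 (0.16 log units; within the scatter), is expected to stay within the scatter of repeated measurements.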

Compound 3, solubility: 350000 ug/mL
Beside the measured number, compound 3's estimate is 1.8-fold (0.24 log units) below it; low and high end bracket the measured number.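

In this assay, going by these compounds alone, the change from dimethylamino to (dimethylamino)methyl, on a saturated chain carbon, three bonds along the chain from an oxygen on an aromatic ring, gives a 1.2-fold higher number from compound 2 to compound 3 (0.08 log units; within the scatter), the first step that can be read. This is new: with only compound 2 measured as a number, nothing could be said about this position, whereas the 3-(dimethylamino)propyl and 4-(dimethylamino)butyl chains now read alike in this assay. Nothing at hand bears on why the two chains read alike.

Compound 1 is reported only as a limit, and steps to it cannot be read: the limit of < 1000 ug/mL in this assay, at which 1 of the 3 values shown sits. As far as these compounds go, it remains open whether the same flat reading holds for a shorter chain such as 2-(dimethylamino)ethyl, for a longer chain such as 5-(dimethylamino)pentyl, or for a morpholine or a carboxylic acid in place of dimethylamino at the chain end.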